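A Methoxy Group Added to a Serotonin Receptor Ligand

This account rests on a few compounds, and the source may have more. Where it says the series, first, only, none or still open, it means among the compounds named here.

Measured so far:
Compound 1, `O=S(=O)(c1ccccc1)c1cn(C2CCNCC2)c2ccccc12`: 91 nM
Compound 2, `O=S(=O)(c1cccc(F)c1)c1cn(C2CCCNC2)c2ccccc12`: 6 nM

In an assay on HeLa cells for displacement of a labelled ligand from 5-hydroxytryptamine receptor 6 (Homo sapiens), with a stated time of 2 h (on this read-out higher numbers stand for weaker inhibition and lower numbers for stronger inhibition), compound 1 gives 91 nM and compound 2 gives 6 nM. Compound 2 thus stands at the lowest of the two numbers, the stronger binder, while compound 1 sits at a clearly higher number, beyond the scatter. Among the compounds with values here, no single step between the two is recorded, since they differ in more than one place.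

Compound 3, `COc1ccc2c(c1)c(S(=O)(=O)c1cccc(F)c1)cn2C1CCCNC1`, is not yet measured. It differs from compound 2 in one place: methoxy in place of hydrogen on an aromatic carbon. Within the data shown here, no measured pair shows the effect of this change, so the expectation rests on compound 2 alone. The step from compound 2 to compound 3 in this assay is expected to be small, toward a lower number if any, and likely within the scatter, a 1.5-fold lower number from compound 2 to compound 3 (0.18 log units; within the scatter). Compound 3 is therefore estimated at 4 nM, with a range from 1.5 nM to 12 nM.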

Compound 3, inhibition constant: 10.7 nM
Estimate against measurement, compound 3: 2.7-fold (0.43 log units) below; measured number inside the range.
By their numbers in this assay, from the lowest: compounds 2 and 3 (each within the scatter of the next); then compound 1.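

In this assay, placing a methoxy group on this aromatic carbon of the shared core gives a 1.8-fold higher number from compound 2 to compound 3 (0.25 log units; within the scatter), so compound 2 and compound 3 cannot be told apart. Compound 2 has only hydrogen at this carbon, so it could not show what a group there would do; compound 3 shows that a methoxy group, meta to one fused ring and para to the other, leaves the binding number within normal assay variation. Nothing shown here gives a reason for this result.

Still open, from the compounds shown here alone, is whether a different group on this same carbon, such as an amine, a carboxylic acid or a longer chain like butoxy, would also leave the number unchanged. Also open, going by these compounds, is whether methoxy would give a similar step on the core of compound 1.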